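Hydroxylated Cyclopropyl Analogue and Expected Cytotoxicity

The compounds below may be only part of what the source reports. "The series", "measured", "known", "first", "only" and "open" are said of these compounds alone.

Compound 2 `CC(C)C(Nc1nc(Cl)nc2c1ncn2[C@H]1[C@H](O)[C@H](O)[C@]2(CO)C[C@H]12)C(C)C` was tested in an ADME assay on Vero 76 cells (Chlorocebus sabaeus) for cytotoxicity, read by neutral red uptake; on this read-out higher numbers stand for lower toxicity in this test and lower numbers for higher toxicity in this test. In this assay compound 2 gives > 100000 nM, a limit of the assay rather than a number. Compound 3 `OC[C@H]1O[C@@H](n2cnc3c(NC(C4CCC4)C4CCC4)ncnc32)[C@H](O)[C@@H]1O` gives > 100000 nM, also a limit. Compound 1 `CC[C@@H](Nc1nc(SC)nc2c1ccn2[C@H]1[C@H](O)[C@H](O)[C@]2(CO)C[C@H]12)C1CC1` gives > 50000 nM, again a limit. Compound 2 thus stands at the limit of > 100000 nM in this assay, at which 2 of the 3 values shown sit. Compound 1 sits at the limit of > 50000 nM in this assay, at which 1 of the 3 values shown sits. For the measured compounds named here, all three values are limits, so no measured step between any pair can be read from them. Compound 4 `CC(C)(O)[C@@H](Nc1nc(Cl)nc2c1ncn2[C@H]1[C@H](O)[C@H](O)[C@]2(CO)C[C@H]12)C1CC1` has not been measured; it carries 1-cyclopropyl-2-hydroxy-2-methylpropyl in place of 1-isopropyl-2-methylpropyl on a nitrogen on an aromatic ring. Compound 4 is expected to sit at a limit as well, around 100000 nM, within a range from 50000 nM to 300000 nM. The estimated step of a number no higher from compound 2 to compound 4 (the limit leaves the size open) is expected to be none beyond the scatter.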

Compound 4, half-maximal cytotoxic concentration: > 100000 nM
Compound 4: only a limit was reported; the forecaster's own chance of this, stated with the estimate: 85%; the middle value sits exactly at the limit.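

Compound 2 and compound 4 are both reported only as limits in this assay, and the step between them cannot be read. The compounds shown leave open at what concentration any of them turns toxic in this assay.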